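The source may report more compounds than this note shows. Statements on the series, on what has been measured and on what is new or still open speak of the compounds shown alone.

Measured so far:
- compound 1, `COc1cc(/C=N/NC(=O)Nc2ccc(Oc3ccnc(-c4nncn4CCN(C)C)c3)c(F)c2)cc(OC)c1OC`: 2770 nM
- compound 2, `CN(C)CCn1cnnc1-c1cc(Oc2ccc(NC(=O)N/N=C/c3cccc(Cl)c3Cl)cc2F)ccn1`: 72 nM

In a functional assay on NCI-H460 cells (Homo sapiens) for cytotoxicity, read by MTT assay, with a stated time of 72 h (a higher number here means a weaker inhibitor, a lower number a stronger inhibitor), compound 2 gives 72 nM, the lowest of the two numbers; its nearest neighbour is compound 1 with 2770 nM. Going by the values given here, the one measured step, a 38-fold lower number from compound 1 to compound 2 (1.59 log units; beyond the scatter), swaps the whole aryl group. Compound 3, `CN(C)CCn1cnnc1-c1cc(Oc2ccc(NC(=O)N/N=C/c3ccc(F)cc3Cl)cc2F)ccn1`, differs from compound 2 only in 2-chloro-4-fluorophenyl in place of 2,3-dichlorophenyl on a carbon with a double bond to nitrogen. Among the compounds with values here, no measured step touches this swap; one chlorine is kept, so a step far smaller than a 38-fold lower number from compound 1 to compound 2 (1.59 log units; beyond the scatter) is expected, at most a modest loss in this assay. Compound 3 is estimated at 150 nM (range 50 nM to 500 nM), a step of a 2.1-fold higher number from compound 2 to compound 3 (0.32 log units; beyond the scatter).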

Compound 3, half-maximal inhibitory concentration: 720 nM
The estimate for compound 3 lay 4.8-fold (0.68 log units) below the measured number; the measured number lies above the stated range.
By their numbers in this assay, from the lowest: compound 2; then compound 3; then compound 1.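

On the carbon with a double bond to nitrogen, the halogen pattern still counts when one chlorine is kept: in this assay, 2-chloro-4-fluorophenyl in place of 2,3-dichlorophenyl gives a 10-fold higher number from compound 2 to compound 3 (1.00 log units; beyond the scatter) (a step of real size). The same group still compares well with 3,4,5-trimethoxyphenyl, at a 3.8-fold lower number from compound 1 to compound 3 (0.59 log units; beyond the scatter), so compound 3 falls between the two earlier compounds. No supporting data explain this order.

The compounds shown do not separate losing the second chlorine from gaining the fluorine. From the compounds shown here alone, how a phenyl ring bearing a nitrile or a trifluoromethyl would read in this place stays open.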